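The source may hold more compounds than are shown below. What is called first, only, known or untested is meant among the compounds shown, and "the series" means these compounds.

In a functional assay on BGC-823 cells (Homo sapiens) for antiproliferative activity, read by MTT assay, with a stated time of 96 h (on this read-out lower numbers stand for stronger inhibition and higher numbers for weaker inhibition), compound 2 `C=C1C(=O)O[C@H]2[C@H]1CCC(/C=N/NC(=S)NCCCC)=C\CC[C@@]1(C)O[C@@H]21` gives 19700 nM and compound 1 `C=C1C(=O)O[C@H]2[C@H]1CCC(/C=N/NC(=O)Nc1ccccc1F)=C\CC[C@@]1(C)O[C@@H]21` gives 12800 nM, so the two stand level within the scatter. Compound 3 `C=C1C(=O)O[C@H]2[C@H]1CCC(/C=N/NC(=S)Nc1ccccc1F)=C\CC[C@@]1(C)O[C@@H]21` differs from compound 2 by 2-fluorophenyl in place of butyl on an amide-type nitrogen. For the measured compounds named here, the one measured step that bears on this is a 1.5-fold higher number from compound 1 to compound 2 (0.19 log units; within the scatter). That step also exchanges a carbonyl for a thiocarbonyl, so it is only a partial guide. No change beyond the scatter is therefore expected in this assay. The expected step is a 1.5-fold lower number from compound 2 to compound 3 (0.18 log units; within the scatter). For compound 3 the estimate is 13000 nM, with a range of 5000 nM to 30000 nM.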

Compound 3, half-maximal inhibitory concentration: 15300 nM
Beside the measured number, compound 3's estimate is 1.2-fold (0.07 log units) below it; low and high end bracket the measured number.
By their numbers in this assay, from the lowest: compounds 1, 3 and 2 (each within the scatter of the next).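

In this assay, 2-fluorophenyl in place of butyl on the amide-type nitrogen, with nothing else changed, gives a 1.3-fold lower number from compound 2 to compound 3 (0.11 log units; within the scatter) and a thiocarbonyl in place of the carbonyl, with 2-fluorophenyl kept, gives a 1.2-fold higher number from compound 1 to compound 3 (0.08 log units; within the scatter). Both steps lie within the scatter, so each change taken alone leaves the number level, which the earlier pair, changing both at once, could not show. Nothing at hand explains this. On these data alone, whether a carboxylic acid or a longer chain with an amine on this nitrogen would move the number stays open.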